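Swapping a Benzyl Ester for a Trifluoroethyl Ester

This account rests on a few compounds, and the source may have more. Where it says the series, first, only, none or still open, it means among the compounds named here.

Compound 1 `O=C(OCc1ccccc1)c1ccsc1NC(=O)[C@@H]1CCCN1` was tested in a functional assay on MCF7 cells (Homo sapiens) for inhibition; a lower number here means a stronger inhibitor of growth, a higher number a weaker inhibitor of growth. In this assay compound 1 gives only a limit, > 250 ug/mL. Compound 2 `CCOC(=O)c1ccsc1NC(=O)[C@@H]1CCCN1` also reaches only a limit in this assay, > 250 ug/mL. Compound 3 `O=C(OCC(Cl)(Cl)Cl)c1ccsc1NC(=O)[C@@H]1CCCN1` likewise gives only a limit, > 250 ug/mL. The steps a step that the two limits leave unreadable from compound 1 to compound 2, a step that the two limits leave unreadable from compound 1 to compound 3 and a step that the two limits leave unreadable from compound 2 to compound 3 cannot be sized because all three values sit at the limit of > 250 ug/mL in this assay, at which 3 of the 3 values shown sit. Compound 4 `O=C(OCC(F)(F)F)c1ccsc1NC(=O)[C@@H]1CCCN1` differs from compound 1 by trifluoromethyl in place of phenyl on a saturated chain carbon bound to an oxygen next to a carbonyl group. The three measured steps bear on this change but give no readable size, so no step beyond the scatter can be expected in either direction. Compound 4 is expected to give 300 ug/mL, with a range from 100 ug/mL to 1000 ug/mL, most likely again only a limit. The expected step is a step that the limit leaves unreadable from compound 1 to compound 4.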

Compound 4, concentration for 50% growth inhibition: 89.7 ug/mL
Compound 4: the middle estimate sits 3.3-fold (0.52 log units) above what was measured; the measured number lies below the stated range.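

On a saturated chain carbon bound to an oxygen next to a carbonyl group, the group carried can change growth inhibition in this assay: trifluoromethyl brings an at least 2.7-fold lower number from compound 1 to compound 4 (0.44 log units; beyond the scatter), an at least 2.7-fold lower number from compound 2 to compound 4 (0.44 log units; beyond the scatter) and an at least 2.7-fold lower number from compound 3 to compound 4 (0.44 log units; beyond the scatter). Of the four groups shown, only trifluoromethyl gives a readable number. Each step is only a minimum, because its starting compound sits at a limit: the limit of > 250 ug/mL in this assay, at which 3 of the 4 values shown sit.

Going by these compounds, whether a longer fluorinated chain or an amine at this place would lower the number further stays open. On these data alone, the true size of these steps also stays open.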